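The source may hold more compounds than are shown below. What is called first, only, known or untested is meant among the compounds shown, and "the series" means these compounds.

In an assay on HeLa cells for inhibition of sphingosine-1-phosphate transporter SPNS2 (Mus musculus), read by LC-MS, tested at 2 uM (on this read-out higher numbers stand for more inhibition at the one concentration tested (going by the name of the read-out) and lower numbers for less inhibition), compound 1 `CCCCCCCCCCc1ccc(-c2noc(CCCN)n2)cc1` gives 67%, compound 2 `CCCCCCCCCCc1ccc(-c2noc([C@H]3CCCN3)n2)cc1` gives 12%, and compound 3 `CCCCCCCCCCc1ccc(-c2noc([C@@H]3CCC[C@@H](N)C3)n2)cc1` gives 13%. Compound 3 stands second highest of the three numbers: the step reaching it from its nearest neighbour is a number 1 percentage points higher from compound 2 to compound 3 (within the scatter), and the step reaching it from the highest number is a number 54 percentage points lower from compound 1 to compound 3 (beyond the scatter). Compound 4 `CCCCCCCCCCc1ccc(-c2noc(-c3cccc(CN)c3)n2)cc1` differs from compound 3 in one place: 3-(aminomethyl)phenyl in place of 3-aminocyclohexyl on an aromatic carbon. For the measured compounds named here, the only steps that bear on this change are those at the same position, and they show that both 3-aminocyclohexyl and pyrrolidin-2-yl sit far below 3-aminopropyl, while sitting within the scatter of each other. A phenyl bearing an aminomethyl group is not covered by any measured step, so the direction is uncertain; compound 4 is estimated at 35%, between 5% and 70%, which would mean a step of a number 22 percentage points higher from compound 3 to compound 4 (beyond the scatter) in this assay.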

Compound 4, a percentage reported as inhibition, at one concentration (the size of the read-out at that concentration, not a potency): 2%
Compound 4: middle estimate off by 33 percentage points, on the high side; the measured number lies below the stated range.
By their numbers in this assay, from the lowest: compounds 4, 2 and 3 (each within the scatter of the next, the first and the last beyond it); then compound 1.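

The aromatic ring of 3-(aminomethyl)phenyl does not restore inhibition: the change gives a number 11 percentage points lower from compound 3 to compound 4 (beyond the scatter) and a number 10 percentage points lower from compound 2 to compound 4 (within the scatter) and also a number 65 percentage points lower from compound 1 to compound 4 (beyond the scatter). Across the four compounds, all three ring-bearing groups now sit far below the open-chain 3-aminopropyl, and none of the ring-bearing compounds goes against this. No measurement shown explains the loss. Still open, on these data alone, is whether a shorter or longer amine chain, such as 2-aminoethyl or 4-aminobutyl, would keep inhibition, and whether 3-hydroxypropyl or a carboxylic acid could replace the amine.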